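A few compounds are considered here, and "the series" means these few. Any claim that something is new, unique, unknown or untested is made for them only; others in the source may bear on it.

Compound 1 `COc1ccc(/C=C(\C(=O)c2ccc(Br)cc2)S(=O)(=O)c2ccc(Br)cc2)cc1`: 25000 nM
Compound 2 `COc1ccc(/C=C(\C(=O)c2ccc(Cl)cc2)S(=O)(=O)c2ccc(Br)cc2)cc1`: 10000 nM
Compound 3 `O=C(/C(=C\c1ccc(OC(F)(F)F)cc1)S(=O)(=O)c1ccc(Br)cc1)c1ccc(Br)cc1`: 25000 nM

These three compounds were tested in a functional assay on DU-145 cells (Homo sapiens) for inhibition, read by trypan blue exclusion, with a stated time of 96 h; on this read-out higher numbers stand for weaker inhibition of growth and lower numbers for stronger inhibition of growth. On the numbers shown, compound 1 stands level with compound 3, and together they give the highest numbers of the three; compound 2 sits apart from them by a 2.5-fold lower number from compound 1 to compound 2 (0.40 log units; beyond the scatter), a modest step.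

Compound 4 `COc1cccc(OC)c1/C=C(\C(=O)c1ccc(Br)cc1)S(=O)(=O)c1ccc(Br)cc1` has not yet been measured. It differs from compound 1 in one place: 2,6-dimethoxyphenyl in place of 4-methoxyphenyl on a double-bonded chain carbon bound to a double-bonded chain carbon. For the measured compounds named here, no measured pair changes this part of the molecule in the same way. The nearest guide is the step from compound 1 to compound 3, which alters a group on the same aromatic ring and gives no change at the digits printed from compound 1 to compound 3 (within the scatter). The step to compound 2 changes a halogen elsewhere and gives a 2.5-fold lower number from compound 1 to compound 2 (0.40 log units; beyond the scatter). Neither step speaks directly for the new change, so for compound 4 no step beyond the scatter is expected in this assay, in either direction. Compound 4 is therefore estimated at 25000 nM, within a range of 8000 nM to 80000 nM, which is expected to mean a step of no change at the digits printed from compound 1 to compound 4 (within the scatter).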

Compound 4, concentration for 50% growth inhibition: 10000 nM
Beside the measured number, compound 4's estimate is 2.5-fold (0.40 log units) above it; the range from low to high includes it.
By their numbers in this assay, from the lowest: compounds 2 and 4 (each within the scatter of the next); then compounds 1 and 3 (each within the scatter of the next).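

The aryl group on the double-bonded chain carbon can affect the result in this assay: 2,6-dimethoxyphenyl in place of 4-methoxyphenyl gives a 2.5-fold lower number from compound 1 to compound 4 (0.40 log units; beyond the scatter) with a modest gain in growth inhibition. For the compounds shown here, compound 3 also carried a change on this ring, but its step stayed within the scatter, so compound 4 is the first case here in which a change to this ring goes beyond it. The swap alters both the number and the placing of the methoxy groups, and nothing measured here explains the step or separates these two changes.

Going by these compounds, it remains open whether 2,6-dimethoxyphenyl would act the same way alongside the chloro group of compound 2. Also unsettled is how this ring would respond to a hydroxyl group or an amine in place of methoxy.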